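Tolerated concentration across the series, compound 1 to compound 4

The source may hold more compounds than are shown below. What is called first, only, known or untested is meant among the compounds shown, and "the series" means these compounds.

Three measured compounds share a core. Compound 1 `Fc1ccc(-c2nc3cc(C(F)(F)F)ccc3[nH]2)cc1` carries a fluoro group and in an ADME assay on Vero cells (Chlorocebus sabaeus) for cytotoxicity (a higher number here means that more compound is tolerated, a lower number that less compound is tolerated), compound 1 gives 60000 nM. Compound 2 `CC(=O)Nc1ccc(-c2nc3cc(C(F)(F)F)ccc3n2C2CCCCC2)cc1` differs at more than one place; in this assay compound 2 gives 30000 nM. Compound 3 `O=C(CN1CCCCC1)Nc1ccc(-c2nc3ccccc3[nH]2)cc1` in this assay is reported only as a limit, > 100000 nM, not as a number. Among the two plain numbers, compound 1 stands highest, with compound 2 as its nearest neighbour, a gap that sits within the scatter, so no order between compound 1 and compound 2 is claimed. One further value is the limit of > 100000 nM in this assay, at which 1 of the 3 values shown sits.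

Compound 4 `CCN(CC)CC(=O)Nc1ccc(-c2nc3cc(C(F)(F)F)ccc3[nH]2)cc1` is not yet measured. Relative to compound 1 the change is (((diethylamino)methyl)carbonyl)amino in place of fluoro on an aromatic carbon. Among the measured compounds shown here, no step between measured compounds isolates this change. For the measured compounds named here, compound 3, which also carries an acetamide bearing a cyclic amine on its para position and sits at the limit, is the closest precedent, but it differs from compound 4 at the trifluoromethyl position as well. The expected step in this assay is upward and modest, a 1.3-fold higher number from compound 1 to compound 4 (0.10 log units; within the scatter), possibly not beyond the scatter. For compound 4 the estimate in this assay is 75000 nM, ranging from 30000 nM to 160000 nM.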

Compound 4, half-maximal cytotoxic concentration: 24000 nM
Beside the measured number, compound 4's estimate is 3.1-fold (0.49 log units) above it; the measured number lies below the stated range.
By their numbers in this assay, from the lowest: compounds 4, 2 and 1 (each within the scatter of the next, the first and the last beyond it). At a limit, above all of these: compound 3.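

At this aromatic carbon, para to a large group, this assay gives the series its first step that isolates a single place: a 2.5-fold lower number from compound 1 to compound 4 (0.40 log units; beyond the scatter), with (((diethylamino)methyl)carbonyl)amino in place of fluoro. With the rest of compound 1 unchanged, the position therefore responds to this exchange of a single fluorine for a chain of 9 heavy atoms, though only modestly. Compound 3, which carries an acetamide bearing a cyclic amine but differs from compound 4 in more than one place, remains a limit and gives no step for this change: the limit of > 100000 nM in this assay, at which 1 of the 4 values shown sits.

The compounds shown do not separate the contribution of the amide link from that of the diethylamino end, and a simple acetylamino group at this position on the unchanged core of compound 1 would make that reading possible. Also open, going by these compounds, is how this assay would read if a carboxylic acid, a morpholine or a longer chain took the place of the diethylamino end, and so whether the lower number belongs to this chain alone or to any large group at this position.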